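Notes on the biphenyl acid imidazole series, compound 4

This account rests on a few compounds, and the source may have more. Where it says the series, first, only, none or still open, it means among the compounds named here.

Measured so far:
- compound 1, `O=C(O)c1ccccc1-c1ccc(CCc2ncc(Cc3cccc(Cl)c3)[nH]2)cc1`: 31 nM in an in vitro functional assay on cells for agonist activity at Bombesin receptor subtype-3 (Mus musculus), read by luminescence and calcium flux; a lower number here means that less compound is needed, a higher number that more compound is needed for the effect
- compound 2, `O=C(O)c1ccccc1-c1ccc(CCc2ncc(CC3CCC3)[nH]2)cc1`: 7.1 nM
- compound 3, `N#Cc1ccc(Cc2cnc(CCc3ccc(-c4ccccc4C(=O)O)cc3)[nH]2)cc1`: 723 nM

Compound 3 stands highest of the three numbers in this assay; its nearest neighbour is compound 1 and its furthest is compound 2, both steps beyond the scatter.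

Compound 4, `O=C(O)c1ccccc1-c1ccc(CCc2ncc(CCc3ccccc3)[nH]2)cc1`, is not yet measured. The change from compound 3 is benzyl in place of 4-cyanophenyl on a saturated chain carbon bound to an aromatic carbon.

Among the compounds with values here, two measured steps bear on it, since each ends at the 4-cyanophenyl group that now leaves. Going a 23-fold higher number from compound 1 to compound 3 (1.37 log units; beyond the scatter) and going a 100-fold higher number from compound 2 to compound 3 (2.01 log units; beyond the scatter): in both the arrival of 4-cyanophenyl brought a large rise in the number, and the substituent without the nitrile gave the lower value. Nothing measured carries a benzyl group at this carbon, so the exact landing point is open; the aromatic ring stays, which keeps compound 4 closer to compound 1 than to compound 2 in kind.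

The expectation for compound 4 is therefore a large step downward in this assay from compound 3, a 24-fold lower number from compound 3 to compound 4 (1.38 log units; beyond the scatter), beyond the scatter. Compound 4 is estimated at 30 nM, with a range from 8 nM to 120 nM.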

Compound 4, half-maximal effective concentration: 174 nM
Compound 4: the middle estimate sits 5.8-fold (0.76 log units) below what was measured; the whole stated range lies below it.
By their numbers in this assay, from the lowest: compound 2; then compound 1; then compound 4; then compound 3.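

In this assay, exchanging 4-cyanobenzyl for phenethyl on this saturated chain carbon gives a 4.2-fold lower number from compound 3 to compound 4 (0.62 log units; beyond the scatter) and no more, so losing the nitrile while keeping an aromatic ring undoes only part of the high number of compound 3. The phenethyl group also stays behind both other groups, with a 5.6-fold higher number from compound 1 to compound 4 (0.75 log units; beyond the scatter) and a 25-fold higher number from compound 2 to compound 4 (1.39 log units; beyond the scatter) in this assay, which leaves the cyclobutyl-bearing compound 2 with the lowest number of the four and places all three compounds with an aromatic ring at this position above it. No measurement at hand accounts for any of these steps.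

The compounds shown leave open how much of the step from 4-cyanobenzyl to phenethyl belongs to the nitrile and how much to the longer link, a split that an unsubstituted phenyl on the same chain carbon would help to settle. They also leave open whether the low number of compound 2 is particular to cyclobutyl or extends to other saturated groups such as cyclopentyl or cyclohexyl, or to a longer chain ending in cyclobutyl.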